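Changing the Ester Group on a Shared Core

The compounds below may be only part of what the source reports. "The series", "measured", "known", "first", "only" and "open" are said of these compounds alone.

Measured so far:
Compound 1 `C/C=C(/C)C(=O)O[C@@H]1C/C=C(\C)CCCC(C)(C)[C@@H](OC(C)=O)/C=C\1C` — in a functional assay on K562 cells (Homo sapiens) for cytotoxicity, read by MTT assay (on this read-out lower numbers stand for stronger inhibition and higher numbers for weaker inhibition), compound 1 gives > 50000 nM, a limit of the assay.
Compound 2 `CC(=O)O[C@H]1/C=C(/C)[C@H](OC(=O)c2ccccc2)C/C=C(\C)CCCC1(C)C` — in this assay compound 2 gives > 50000 nM, also a limit.

Compound 2 thus stands at the limit (the limit of > 50000 nM in this assay, at which 2 of the 2 values shown sit), and the step that the two limits leave unreadable from compound 1 to compound 2 cannot be read. Compound 3 `COc1cc(C(=O)O[C@@H]2C/C=C(\C)CCCC(C)(C)[C@@H](OC(C)=O)/C=C\2C)ccc1O` differs from compound 2 by 4-hydroxy-3-methoxyphenyl in place of phenyl on a carbonyl carbon. For the measured compounds named here, no measured step bears on this change, since both measured values are limits (the limit of > 50000 nM in this assay, at which 2 of the 2 values shown sit). Compound 3 is expected to stay at or near the limit as well, estimated at 60000 nM with a range of 20000 nM to 200000 nM. The expected step that the limit leaves unreadable from compound 2 to compound 3 is an estimate only.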

Compound 3, half-maximal inhibitory concentration: 41500 nM
For compound 3 the middle estimate is 1.4-fold (0.16 log units) above the measured one; measured number inside the range.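

In this assay, for the compounds shown here, compound 3 is the only one of the three compounds to give a measured number rather than a limit, so this ester position can now register a change, which the unreadable step between compound 1 and compound 2 could not show. With 4-hydroxy-3-methoxyphenyl on the carbonyl carbon, the data show an at least 1.2-fold lower number from compound 2 to compound 3 (0.08 log units; that floor lies within the scatter) and an at least 1.2-fold lower number from compound 1 to compound 3 (0.08 log units; that floor lies within the scatter). Both are only floors, and most values remain limits: the limit of > 50000 nM in this assay, at which 2 of the 3 values shown sit.

Which part of 4-hydroxy-3-methoxyphenyl matters stays open. So does how an amine or a longer chain in its place would read.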